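Cytotoxicity of a bromobenzyl analogue estimated from limits

The source may report more compounds than this note shows. Statements on the series, on what has been measured and on what is new or still open speak of the compounds shown alone.

In a toxicity assay on NIH3T3 cells (Mus musculus) for cytotoxicity, read by resazurin assay (on this read-out higher numbers stand for an effect only at larger amounts of compound and lower numbers for an effect already at smaller amounts), compound 3 `COC(=O)c1ccc(NCc2cncn2Cc2ccc(F)cc2F)cc1-c1ccccc1` stands only at a limit of the assay. In this assay compound 3 gives > 1000 nM, which is a limit and not a number. Compound 1 `COC(=O)c1ccc(NCc2cncn2Cc2ccc(C)cc2)cc1-c1ccccc1` carries a 4-methylphenyl on a saturated chain carbon bound to an aromatic nitrogen, and in this assay compound 1 gives 50000 nM. Compound 2 `COC(=O)c1ccc(NCc2cncn2Cc2cccc(Br)c2)cc1-c1ccccc1` carries a 3-bromophenyl at the same place. In this assay compound 2 gives > 10000 nM, which is a limit. Compound 4 `COC(=O)c1ccc(NCc2cncn2Cc2ccc(Br)cc2)cc1-c1ccccc1` differs from compound 3 as follows: 4-bromophenyl in place of 2,4-difluorophenyl on a saturated chain carbon bound to an aromatic nitrogen. For the measured compounds named here, the steps that bear on it are a step that the limit leaves unreadable from compound 1 to compound 2, a step that the limit leaves unreadable from compound 1 to compound 3 and a step that the two limits leave unreadable from compound 2 to compound 3, all of them unreadable owing to the limit of > 1000 nM in this assay, at which 1 of the 3 values shown sits, and (the limit of > 10000 nM in this assay, at which 1 of the 3 values shown sits). The three aryl changes at this place therefore give no readable size, and compound 4 is expected to sit near the others, most likely again at a limit. The expected step that the limit leaves unreadable from compound 3 to compound 4 is thus no step beyond the scatter. Compound 4 is estimated at 30000 nM, between 5000 nM and 100000 nM.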

Compound 4, half-maximal effective concentration: > 10000 nM
Compound 4: only a limit was reported (the forecaster's own chance of this, stated with the estimate: 60%); the middle value is on the limit's open side.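

For the compounds shown here, compound 4 also stands only at a limit, so no step from it to compound 1, compound 2 or compound 3 can be read. Where compound 2, compound 3 and compound 4 truly lie in this assay, and whether their aryl groups differ there at all, stays open.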